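A Second Halogen on the Hydroxyphenyl Ring

The source may report more compounds than this note shows. Statements on the series, on what has been measured and on what is new or still open speak of the compounds shown alone.

Among the measured compounds shown here, in a functional assay on BGC-823 cells (Homo sapiens) for cytotoxicity, read by MTT assay, with a stated time of 48 h (on this read-out lower numbers stand for stronger inhibition and higher numbers for weaker inhibition), compound 2 `O=C(CSc1nnc(-c2ccncc2)o1)N/N=C/c1cc(Br)ccc1O` gives 9590 nM, the highest of the two numbers measured so far. Its nearest neighbour is compound 1 `O=C(CSc1nnc(-c2ccncc2)o1)N/N=C/c1ccccc1O`, which in this assay gives 6160 nM. For the measured compounds named here, the only measured step, a 1.6-fold higher number from compound 1 to compound 2 (0.19 log units; within the scatter), lies within the scatter. Compound 3 `O=C(CSc1nnc(-c2ccncc2)o1)N/N=C/c1cc(Cl)cc(Cl)c1O` carries 3,5-dichloro-2-hydroxyphenyl in place of 5-bromo-2-hydroxyphenyl on a carbon with a double bond to nitrogen. Going by the values given here, the step that bears on this change is the one from compound 1 to compound 2, in which bromo replaced hydrogen on an aromatic carbon and the number did not move beyond the scatter. A second halogen combined with an exchange of halogen has no measured precedent among these compounds. Compound 3 is therefore expected to show only a 1.1-fold higher number from compound 2 to compound 3 (0.06 log units; within the scatter), leaning toward a higher number but not beyond the scatter. The estimate for compound 3 in this assay is 11000 nM, expected to fall between 4500 nM and 27000 nM.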

Compound 3, half-maximal inhibitory concentration: 6340 nM
Compound 3: the middle estimate sits 1.7-fold (0.24 log units) above what was measured; low and high end bracket the measured number.
By their numbers in this assay, from the lowest: compounds 1, 3 and 2 (each within the scatter of the next).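

In this assay, 3,5-dichloro-2-hydroxyphenyl in place of 5-bromo-2-hydroxyphenyl on the carbon with a double bond to nitrogen gives a 1.5-fold lower number from compound 2 to compound 3 (0.18 log units; within the scatter) and, set against the plain 2-hydroxyphenyl of compound 1, the same group gives a 1.0-fold higher number from compound 1 to compound 3 (0.01 log units; within the scatter) as its step. A second halogen, and chlorine in place of bromine, therefore did not separate compound 3 from either neighbour, so all three compounds at this position now stand within the scatter of one another. No supporting data bear on why this position stays so flat.

As far as these compounds go, whether a group other than a halogen on this ring, such as a methoxy group, an amine or a carboxylic acid, would move the number beyond the scatter stays open. So does the effect of a methyl ether in place of the ring's hydroxyl.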